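This account rests on a few compounds, and the source may have more. Where it says the series, first, only, none or still open, it means among the compounds named here.

Measured compounds in a functional assay on 786-0 cells (Homo sapiens); on this read-out lower numbers stand for stronger inhibition of growth and higher numbers for weaker inhibition of growth:

Compound 1 `COc1ccccc1-c1cc(O)c2ccc(C)nc2n1` gives only a limit of the assay, > 100000 nM (the limit of > 100000 nM in this assay, at which 1 of the 3 values shown sits).
Compound 2 `COc1ccccc1-c1cc(O)c2cccnc2n1` gives 36300 nM.
Compound 3 `COc1cccc(-c2cc(O)c3c(C)ccnc3n2)c1` gives 51.3 nM.

Within the data shown here, the one step between measured compounds that differ in a single place is hydrogen in place of methyl on an aromatic carbon. That change gives an at least 2.7-fold lower number from compound 1 to compound 2 (0.44 log units; beyond the scatter); since the value of compound 1 is a limit, the size of this step is known only as a lower bound. Compound 3 sits far apart from compound 2, the difference between the two cores being not broken down here.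

Compound 4 `COc1cccc(-c2cc(O)c3cccnc3n2)c1` is not yet measured. It differs from compound 3 by hydrogen in place of methyl on an aromatic carbon. This is the same kind of change as from compound 1 to compound 2, but not the same: in compound 1 the methyl sits next to the ring nitrogen, meta to a fused ring and para to a fused ring, whereas in compound 3 it sits ortho to a fused ring, meta to a fused ring and opposite the ring nitrogen. Among the measured compounds shown here, the earlier step is the only guide and rests on a limit, so the expected step is set near zero: a 1.1-fold lower number from compound 3 to compound 4 (0.06 log units; within the scatter). For compound 4 the estimate in this assay is 45 nM, expected between 12 nM and 180 nM.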

Compound 4, concentration for 50% growth inhibition: 61.7 nM
Compound 4: middle estimate off by 1.4-fold (0.14 log units), on the low side; the range from low to high includes it.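

Hydrogen in place of methyl on an aromatic carbon, ortho to a fused ring and opposite the ring nitrogen, gives in this assay a 1.2-fold higher number from compound 3 to compound 4 (0.08 log units; within the scatter). This change therefore does not carry from one core to the other as a single fixed step: the same change on two cores in this assay, an at least 2.7-fold lower number (0.44 log units; beyond the scatter) from compound 1 to compound 2 and a 1.2-fold higher number (0.08 log units; within the scatter) from compound 3 to compound 4, at least 3.3-fold (0.52 log units) apart, beyond the scatter of two such steps

Compound 1 stands at a limit, > 100000 nM, so the earlier step is only a lower bound, and the two pairs do not show whether the difference between the steps comes from the place of the methyl or from the rest of each core.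

Open, going by these compounds, is what the carbon bearing the methyl in compound 3 accepts beyond hydrogen and methyl, for instance an amine, a carboxylic acid or a longer chain such as propyl. Among these compounds, also open is whether the near-absent effect of the methyl on the core of compound 3 would hold on further cores, since only two cores carry this change here.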